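Pyrazole chalcone series: growth inhibition notes on OVCAR-8

This account rests on a few compounds, and the source may have more. Where it says the series, first, only, none or still open, it means among the compounds named here.

Measured so far:
compound 1 `COc1ccc(-c2cc(/C=C/C(=O)c3ccc(OC)c(OC)c3)[nH]n2)cc1` gives 2160 nM
compound 2 `COc1cc(-c2cc(/C=C/C(=O)c3ccc(Cl)c(Cl)c3)[nH]n2)cc(OC)c1OC` gives 6300 nM
compound 3 `COc1ccc(-c2cc(/C=C/C(=O)c3ccc(N)cc3)[nH]n2)cc1` gives 2440 nM

The three values above come from a functional assay on OVCAR-8 cells (Homo sapiens) for inhibition, read by sulforhodamine B assay, with a stated time of 48 h; a higher number here means a weaker inhibitor of growth, a lower number a stronger inhibitor of growth. Compound 2 stands highest of the three numbers; its nearest neighbour is compound 3, whose number is lower by a margin beyond the scatter, and the furthest is compound 1, also lower by a margin beyond the scatter. Compound 1 and compound 3 lie within the scatter of each other, so no order is claimed between them. Within the data shown here, no step between measured compounds differing in a single place is available, so the following expectation rests on the values alone.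

Compound 4 `COc1ccc(C(=O)/C=C/c2cc(-c3cc(OC)c(OC)c(OC)c3)n[nH]2)cc1OC` is not yet measured. It differs from compound 2 in one place: 3,4-dimethoxyphenyl in place of 3,4-dichlorophenyl on a carbonyl carbon. Compound 1 also carries the 3,4-dimethoxyphenyl on the carbonyl carbon and gives 2160 nM, which is lower than the number for compound 2. A downward step of modest size, possibly only at the edge of the scatter, is expected in this assay, namely a 2.0-fold lower number from compound 2 to compound 4 (0.29 log units; within the scatter). Compound 4 is therefore estimated at 3200 nM, with a range from 1300 nM to 8000 nM.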

Compound 4, concentration for 50% growth inhibition: 1320 nM
Estimate against measurement, compound 4: 2.4-fold (0.38 log units) above; the measured number falls inside the stated range.
By their numbers in this assay, from the lowest: compounds 4, 1 and 3 (each within the scatter of the next); then compound 2.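

This step is the only single-place comparison shown in the series: in this assay, 3,4-dimethoxyphenyl in place of 3,4-dichlorophenyl on a carbonyl carbon gives a 4.8-fold lower number from compound 2 to compound 4 (0.68 log units; beyond the scatter) and lies beyond the scatter. The group on the carbonyl carbon therefore matters for growth inhibition in this background, since the rest of compound 4 matches compound 2, whereas the earlier values could not separate this group from the other differences among compounds 1, 2 and 3. Nothing available explains the size or direction of the step, so it stands as an observation on these two structures only.

One step on one background leaves open whether the same change would carry over to the core of compound 1 or compound 3, and whether both methoxy groups are needed or one alone would give a similar number. Also open, going by these compounds, is how other groups on the carbonyl carbon would compare in this assay, such as 3,4-difluorophenyl or a phenyl ring bearing a carboxylic acid.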